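Taking the Chloro Group Away from the Best Compound

The source may report more compounds than this note shows. Statements on the series, on what has been measured and on what is new or still open speak of the compounds shown alone.

Compound 1 `O=C(NO)c1cccc(OCc2ccc(-c3ccccc3)cc2)c1` gives 19600 nM in an assay on isolated protein for inhibition of sphingomyelin phosphodiesterase (Homo sapiens), read by fluorescence, with a stated time of 30 min; on this read-out higher numbers stand for weaker inhibition and lower numbers for stronger inhibition.
Compound 2 `O=C(NO)c1cccc(OCc2ccc(-c3ccc(Cl)cc3)cc2)c1` gives 8960 nM in this assay.
Compound 3 `COc1ccc(C(=O)NO)cc1OCc1ccc(-c2ccc(Cl)cc2)cc1` gives 340 nM in this assay.

Compound 3 stands lowest of the three numbers, meaning it is the strongest inhibitor measured. Its nearest neighbour is compound 2, reached by a large step: a 26-fold lower number from compound 2 to compound 3 (1.42 log units; beyond the scatter), which comes from a methoxy in place of hydrogen on an aromatic carbon. Compound 1 gives the highest number of all and lies furthest away.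

Compound 4 `COc1ccc(C(=O)NO)cc1OCc1ccc(-c2ccccc2)cc1` has not yet been measured. It differs from compound 3 in one place: hydrogen in place of chloro on an aromatic carbon, placed para to a large group. Within the data shown here, the one measured step that bears on this change is the reverse of it, a 2.2-fold lower number from compound 1 to compound 2 (0.34 log units; beyond the scatter), where chloro entered in place of hydrogen and the number fell by a modest amount. Running that change backwards, the number is expected to rise, again modestly, since compound 1 and compound 2 showed no more than that. The expected step is a 2.2-fold higher number from compound 3 to compound 4 (0.34 log units; beyond the scatter). Compound 4 is therefore estimated at 750 nM in this assay, within a range from 300 nM to 2000 nM.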

Compound 4, half-maximal inhibitory concentration: 3630 nM
Beside the measured number, compound 4's estimate is 4.8-fold (0.68 log units) below it, and the stated range ends below it.
By their numbers in this assay, from the lowest: compound 3; then compound 4; then compound 2; then compound 1.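

In this assay, going from 4-chlorophenyl to phenyl on the core that carries the methoxy group gives an 11-fold higher number from compound 3 to compound 4 (1.03 log units; beyond the scatter), so the chloro group counts for far more on this core than on the core of compound 1: the same change on two cores in this assay, a 2.2-fold lower number (0.34 log units; beyond the scatter) from compound 1 to compound 2 and an 11-fold lower number (1.03 log units; beyond the scatter) from compound 4 to compound 3, 4.9-fold (0.69 log units) apart, beyond the scatter of two such steps

The methoxy group, until now seen only with the chloro group present, also lowers the number without it, giving a 5.4-fold lower number from compound 1 to compound 4 (0.73 log units; beyond the scatter), though by less than when the chloro group is there: the same change on two cores in this assay, a 26-fold lower number (1.42 log units; beyond the scatter) from compound 2 to compound 3 and a 5.4-fold lower number (0.73 log units; beyond the scatter) from compound 1 to compound 4, 4.9-fold (0.69 log units) apart, beyond the scatter of two such steps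

Across these four compounds the two groups therefore do not act independently, as each lowers the number further when the other is present, and compound 3, which carries both, stands lowest, with its steps to all the others beyond the scatter.

The compounds shown have only hydrogen or chloro at this place, so it stays open whether a fluoro, bromo or methyl group there would work together with the methoxy group in the same way. Going by these compounds, it also stays open whether an ethoxy or hydroxy group could take the place of the methoxy group and keep this link, and the numbers alone do not say what underlies it.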